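The source may report more compounds than this note shows. Statements on the series, on what has been measured and on what is new or still open speak of the compounds shown alone.

Notes on the series, step from compound 3 to compound 4.

Three compounds have numbers in a physicochemical assay for solubility, in phosphate buffer, measured as kinetic solubility, with a stated time of 18 h, at pH 7.4; a higher number here means a more soluble compound, a lower number a less soluble compound. Compound 1 `O=C(Nc1ccc(Cl)cc1)c1cc([N+](=O)[O-])ccc1Cl` gives 3000 nM. Compound 2 `C=C(C)C(=O)Nc1cccc(-c2nc3ccccc3s2)c1` gives 420 nM. Compound 3 `O=C(O)/C=C/C(=O)Nc1cccc(-c2nc3ccccc3s2)c1` gives 56000 nM, the highest of the three, with compound 1 next and compound 2 furthest away. Among the measured compounds shown here, the only single-point step among the measured compounds is a 130-fold higher number from compound 2 to compound 3 (2.12 log units; beyond the scatter), which came with 2-carboxyethenyl in place of 1-methylethenyl on the carbonyl carbon.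

Compound 4 `O=C(Nc1cccc(-c2nc3ccccc3s2)c1)c1cccnc1Cl` is not yet measured. Compared with compound 3 the change is 2-chloropyridin-3-yl in place of 2-carboxyethenyl on a carbonyl carbon. For the measured compounds named here, no measured pair shows exactly this exchange. What bears on it is the step from compound 2 to compound 3, in which the 2-carboxyethenyl group entered and the number rose by a large margin; here that group leaves again, and a six-membered aromatic ring with a chlorine enters instead. Compound 1, which also carries a chlorinated aryl on the carbonyl carbon, sits well below compound 3. A large fall in this assay is therefore expected, a 37-fold lower number from compound 3 to compound 4 (1.57 log units; beyond the scatter), landing in the region of compound 1 rather than compound 2. For compound 4 the expected value is 1500 nM, within 300 nM to 8000 nM.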

Compound 4, solubility: 520 nM
For compound 4 the middle estimate is 2.9-fold (0.46 log units) above the measured one, and the stated range covers the measured number.
By their numbers in this assay, from the lowest: compounds 2 and 4 (each within the scatter of the next); then compound 1; then compound 3.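

On the carbonyl carbon whose other neighbour is the amide-type nitrogen, in this assay the exchange of 2-carboxyethenyl for 2-chloropyridin-3-yl gives a 110-fold lower number from compound 3 to compound 4 (2.03 log units; beyond the scatter), so the large rise seen when 2-carboxyethenyl entered is lost again with an aromatic group at this place. The exchange of 1-methylethenyl for 2-chloropyridin-3-yl gives a 1.2-fold higher number from compound 2 to compound 4 (0.09 log units; within the scatter), so these two quite different groups cannot be told apart here, and among the three groups on the shared core only 2-carboxyethenyl stands out. Nothing on hand gives a reason for this result.

The compounds shown leave open whether a carboxylic acid carried on an aromatic ring at this place would restore the high number. Also open, as far as these compounds go, is whether an amine on the ring, in place of the chlorine, would do the same.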